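Three inactive amides and a hydroxyphenyl analogue

A few compounds are considered here, and "the series" means these few. Any claim that something is new, unique, unknown or untested is made for them only; others in the source may bear on it.

Compound 1 `COc1ccccc1C(=O)Nc1ccc(Sc2nc3ccccc3s2)cc1` in an assay for inhibition of HSP60/HSP10 (Homo sapiens), with a stated time of 60 min (a higher number here means a weaker inhibitor, a lower number a stronger inhibitor), gives > 100000 nM, which is a limit of the assay and not a number.
Compound 2 `O=C(Nc1ccc(Sc2nc3ccccc3s2)cc1)c1ccccc1` in this assay gives > 100000 nM, again only a limit.
Compound 3 `COc1c(Br)cccc1C(=O)Nc1ccc(Sc2nc3ccccc3s2)cc1` in this assay gives > 100000 nM, also a limit.

Compound 3 therefore stands nowhere on a scale of numbers: all three measured compounds sit at the same limit (the limit of > 100000 nM in this assay, at which 3 of the 3 values shown sit), so none can be ordered against another. The steps among them, a step that the two limits leave unreadable from compound 1 to compound 2, a step that the two limits leave unreadable from compound 1 to compound 3 and a step that the two limits leave unreadable from compound 2 to compound 3, are all unreadable for the same reason.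

Compound 4 `O=C(Nc1ccc(Sc2nc3ccccc3s2)cc1)c1ccccc1O` differs from compound 3 by a group of 7 heavy atoms (6 carbon, 1 oxygen; one six-membered aromatic ring of carbon only) in place of a group of 9 heavy atoms (7 carbon, 1 oxygen, 1 bromine; one six-membered aromatic ring of carbon only), on a carbonyl carbon. Because every measured value sits at the limit (the limit of > 100000 nM in this assay, at which 3 of the 3 values shown sit), no measured step gives a direction or size for this change; the shared core with three different aromatic amide groups has shown no measurable inhibition at all. The expectation for compound 4 is therefore a step of no readable size, a number no higher from compound 3 to compound 4 (the limit leaves the size open), most likely ending again at a limit. The estimate for compound 4 in this assay is 100000 nM, within 20000 nM to 300000 nM.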

Compound 4, half-maximal inhibitory concentration: > 100000 nM
Compound 4 ended at the assay's limit; the forecaster's own chance of this, stated with the estimate: 70%; the middle value lies on the limit itself.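

Compound 4 ends at a limit of the assay, as do compound 1, compound 2 and compound 3, so no step among these four compounds can be read: the limit of > 100000 nM in this assay, at which 4 of the 4 values shown sit. The compounds shown leave open whether any amide group on this shared core gives measurable inhibition.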